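Swapping an ether-linked ring for a carbon-linked ring

The source may hold more compounds than are shown below. What is called first, only, known or untested is meant among the compounds shown, and "the series" means these compounds.

Compound 1 `COc1cccc(CCOc2ccc(-c3c(C)nc(C)c([C@H](OC(C)(C)C)C(=O)O)c3N3CCC(C)(C)CC3)cc2)c1` in an ADME assay on microsomes from liver (Homo sapiens) for metabolic stability, read by LC-MS, tested at 0.5 uM (a lower number here means that the compound disappears faster, a higher number that the compound lasts longer), gives > 2 h, which is a limit of the assay and not a number.
Compound 2 `Cc1nc(C)c([C@H](OC(C)(C)C)C(=O)O)c(N2CCC(C)(C)CC2)c1-c1ccc(OCCc2ccc(F)c(F)c2)cc1` in this assay gives > 2 h, also a limit of the assay and not a number.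

Compound 2 therefore stands at the top of what the assay can report, with the limit of > 2 h in this assay, at which 2 of the 2 values shown sit, showing that both known values sit there. For the measured compounds named here, the only measured step, a step that the two limits leave unreadable from compound 1 to compound 2, cannot be read as a size, since both ends are limits; it swaps the ring at the far end of the chain while keeping the ether link.

Compound 3 `Cc1nc(C)c([C@H](OC(C)(C)C)C(=O)O)c(N2CCC(C)(C)CC2)c1-c1ccc(CCCc2ccc(F)cc2)cc1` differs from compound 2 by 3-(4-fluorophenyl)propyl in place of 2-(3,4-difluorophenyl)ethoxy on an aromatic carbon. Here the ether oxygen in the chain is gone and the far ring carries one fluorine rather than two, so this change goes beyond what the step from compound 1 to compound 2 touched. With no readable step to lean on, the expectation is simply that compound 3 lands near where compound 2 stands, as an estimated step of a number no higher from compound 2 to compound 3 (the limit leaves the size open). Compound 3 is thus expected to give about 2 h in this assay, within a range of 0.8 h to 5 h.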

Compound 3, half-life: > 2 h
Compound 3: a limit, no number; the forecaster's own chance of this, stated with the estimate: 55%; the middle value lies on the limit itself.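

Compound 3 gives > 2 h in this assay, again a limit of the assay and not a number. The steps among compound 1, compound 2 and compound 3 therefore cannot be read: the limit of > 2 h in this assay, at which 3 of the 3 values shown sit.

The compounds shown leave open how long each one actually lasts, and whether changing the chain or the far ring alters that half-life at all.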